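The compounds below may be only part of what the source reports. "The series", "measured", "known", "first", "only" and "open" are said of these compounds alone.

Values so far in a physicochemical assay for lipophilicity, at pH 7.4 (on this read-out higher numbers stand for higher lipophilicity and lower numbers for lower lipophilicity), are these:

- Compound 1 `CC(=O)CCc1cc(C)c(Oc2cc(Nc3ccc(C#N)cc3)c(N)cc2C(F)(F)F)c(C)c1` gives > 5 as a limit of the assay, not a number.
- Compound 2 `CNC(=O)c1cc(N)c(Nc2ccc(C#N)cc2)cc1Oc1c(C)cc(CCC#N)cc1C` gives 2.65 as a true number.
- Compound 3 `Cc1cc(/C=C/C#N)cc(C)c1Oc1cc(Nc2ccc(C#N)cc2)c(N)cc1[N+](=O)[O-]` gives > 5 as a limit of the assay, not a number.

Going by the values given here, compound 2 holds the only true number of the three, which makes it the one firm starting point. Compound 4 `Cc1cc(CCC#N)cc(C)c1Oc1cc(Nc2ccc(C#N)cc2)c(N)cc1C(N)=O` has not yet been measured and differs from compound 2 in one place. The difference reads hydrogen in place of methyl on an amide-type nitrogen and, in words, is hydrogen in place of methyl on an amide-type nitrogen, so methylcarbamoyl becomes carbamoyl. Among the compounds with values here, no measured pair here differs in one place only, so the data offer no direct guide to the size of this step. With compound 2 at 2.65 as the base and a single methyl leaving, a small drop in this assay is expected, no larger than the usual scatter. The estimate is an expected a number 0.25 log units lower from compound 2 to compound 4 (within the scatter). For compound 4 the estimate is 2.4 with an expected range from 2 to 2.8 on this scale.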

Compound 4, partition coefficient: 2.65
Beside the measured number, compound 4's estimate is 0.25 log units below it, within the range that was stated.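

In this assay, hydrogen in place of methyl on an amide-type nitrogen, which turns methylcarbamoyl into carbamoyl, gives no change at the digits printed from compound 2 to compound 4 (within the scatter). Going by these compounds alone, this is the first pair in the set that differs in one place only, and so the first direct reading of a single change on this scale. At this position, one methyl can leave that nitrogen with no shift beyond the scatter, something compounds 1 and 3 could not show, since neither differs from compound 2 in one place only.

From the compounds shown here alone, whether an ethyl group or a longer chain on that nitrogen, or a carboxylic acid in place of the whole carbamoyl, would read the same stays open. Any such compound that reached the top of the scale would give no number to compare: the limit of > 5 in this assay, at which 2 of the 4 values shown sit.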